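Swapping an Azetidine for an Oxetane Ether on the Core

The compounds below may be only part of what the source reports. "The series", "measured", "known", "first", "only" and "open" are said of these compounds alone.

Of the compounds shown here, three built on one shared core have been measured in a physicochemical assay for lipophilicity, at pH 7.4; on this read-out higher numbers stand for higher lipophilicity and lower numbers for lower lipophilicity. Compound 1 `Cc1cc(COc2cccc(C#N)c2)nc(-c2ccccn2)n1` gives 2.7 in this assay. Compound 2 `CC(=O)Nc1ccc(OCc2cc(C)nc(-c3ccccn3)n2)cc1` gives 1.9. Compound 3 `CC1(C)CN(c2cc(COc3ccc(F)c(F)c3F)nc(-c3ccccn3)n2)C1` gives 4.3, the highest of the three numbers; its gap to compound 1 is the smaller one and its gap to compound 2 the larger, and both gaps lie beyond the usual scatter of this kind of measurement.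

Compound 4 `COC1(COc2cc(COc3ccc(F)c(F)c3F)nc(-c3ccccn3)n2)COC1` has not yet been measured. It differs from compound 3 in a single place: (3-methoxyoxetan-3-yl)methoxy in place of 3,3-dimethylazetidin-1-yl on an aromatic carbon. The leaving group carries a single hydrogen-bond acceptor, while the entering group carries three, and the entering group is also larger by two heavy atoms, all of them oxygen.

Among the measured compounds shown here, no pair of measured compounds shows this exact swap, so no measured step can be borrowed. A fall in lipophilicity that goes well beyond the scatter is nevertheless expected, with the estimated step from compound 3 to compound 4 in this assay being a number 1.80 log units lower from compound 3 to compound 4 (beyond the scatter). Compound 4 is therefore estimated to give about 2.5, within a range from 1.8 to 3.2.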

Compound 4, distribution coefficient: 3.5
The estimate for compound 4 lay 1.00 log units below the measured number; the measured number lies above the stated range.
By their numbers in this assay, from the lowest: compound 2; then compound 1; then compound 4; then compound 3.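

At this position, on an aromatic carbon of a six-membered aromatic ring with 2 nitrogen, replacing 3,3-dimethylazetidin-1-yl with (3-methoxyoxetan-3-yl)methoxy gives, in this assay, a number 0.80 log units lower from compound 3 to compound 4 (beyond the scatter) and is a modest change. Among the compounds shown here, this is the first step in the set that can be read for a change in one place, since compound 1 and compound 2 each differ from compound 3 in more than one place. No measurement shown gives a cause for the size of this step, so it stands as an observation about this one pair.

As far as these compounds go, the swap changes several things at once: the leaving group has a ring nitrogen bonded directly to the aromatic carbon and two methyl groups, while the entering group brings an oxetane ring, a methoxy group and an oxygen link, so the share of each in the step remains open. From the compounds shown here alone, a plain methoxy group or a morpholin-4-yl group at this position could help separate those shares, and whether the step would hold on a different core also remains open.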